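A few compounds are considered here, and "the series" means these few. Any claim that something is new, unique, unknown or untested is made for them only; others in the source may bear on it.

Working notes on the series. Compound 2 `COc1cc(NC(C)CCCNC(=O)Nc2ccc(F)cc2)c2ncccc2c1` shares its core with compound 1 `COc1cc(NC(C)CCCNC(=O)Nc2cccc(F)c2)c2ncccc2c1` and compound 3 `COc1cc(NC(C)CCCNC(=O)NNC(=O)Nc2cc(C(F)(F)F)cc(C(F)(F)F)c2)c2ncccc2c1`. In a functional assay on NCI-H460 cells (Homo sapiens) for inhibition, read by MTT assay, with a stated time of 72 h (on this read-out higher numbers stand for weaker inhibition and lower numbers for stronger inhibition), compound 2 gives 26000 nM; compound 1 gives 24000 nM and compound 3 gives 18000 nM, both within the usual scatter of the number for compound 2, so no ordering among the three can be claimed. Among the compounds with values here, the one single-point step measured, a 1.1-fold higher number from compound 1 to compound 2 (0.03 log units; within the scatter), is flat. Compound 4 `COc1cc(NC(C)CCCNC(=O)NNC(=O)Nc2ccc(O)cc2)c2ncccc2c1` differs from compound 2 by ((4-hydroxyphenyl)carbamoyl)amino in place of 4-fluorophenyl on an amide-type nitrogen. Within the data shown here, no measured step covers this change directly; compound 3, which also carries a carbamoylamino group on the same amide-type nitrogen, sits within the scatter of compound 2, so the expected step of a 1.2-fold lower number from compound 2 to compound 4 (0.07 log units; within the scatter) is none beyond the scatter. Compound 4 is therefore estimated at 22000 nM, with a range of 9000 nM to 55000 nM.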

Compound 4, half-maximal inhibitory concentration: > 100000 nM
Compound 4: only a limit was reported; the forecaster's own chance of this, stated with the estimate: 15%; middle value at least 4.5-fold (0.65 log units) away from the limit.
By their numbers in this assay, from the lowest: compounds 3, 1 and 2 (each within the scatter of the next). At a limit, above all of these: compound 4.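

In this assay compound 4 gives only a limit, not a number: the limit of > 100000 nM in this assay, at which 1 of the 4 values shown sits. This position on the amide-type nitrogen is therefore not flat, as the fluorine swap alone had suggested: the change gives an at least 3.8-fold higher number from compound 2 to compound 4 (0.58 log units; beyond the scatter) and an at least 4.1-fold higher number from compound 1 to compound 4 (0.61 log units; beyond the scatter). Compound 3, with a carbamoylamino group on the same nitrogen, gives 18000 nM, so that group alone does not go with the loss.

As far as these compounds go, whether the 4-hydroxy group on the ring is what separates compound 4 from compound 3 stays open. A 4-aminophenyl or 4-carboxyphenyl ring on the same carbamoylamino link would bear on this.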